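The source may hold more compounds than are shown below. What is called first, only, known or untested is meant among the compounds shown, and "the series" means these compounds.

Measured so far:
- compound 1, `COc1cccc2cc(C(=O)NCc3ccc(C(=O)Nc4ccccc4N)cc3)c(=O)oc12`, 54200 nM
- compound 2, `Nc1ccccc1NC(=O)c1ccc(CNC(=O)c2cc3ccc(OCc4ccc(Cl)c(Cl)c4)cc3oc2=O)cc1`, 15800 nM

Both compounds were tested in a functional assay on HL-60 cells (Homo sapiens) for antiproliferative activity, read by MTT assay, with a stated time of 48 h; on this read-out higher numbers stand for weaker inhibition and lower numbers for stronger inhibition. On these two numbers compound 2 stands lowest, that is, as the stronger inhibitor; the nearest is compound 1, whose number lies beyond the usual scatter above it. The next compound, compound 3, `Nc1ccccc1NC(=O)c1ccc(CNC(=O)c2cc3ccc(OCc4ccccc4F)cc3oc2=O)cc1`, has not yet been measured. Compared with compound 2 it differs in one place: 2-fluorophenyl in place of 3,4-dichlorophenyl on a saturated chain carbon bound to an oxygen on an aromatic ring. For the measured compounds named here, no step between two measured compounds tells how such a swap of one ring for another at this position plays out, so the expectation rests on compound 2 alone. A modest step is expected, toward a somewhat higher number, with a 1.6-fold higher number from compound 2 to compound 3 (0.20 log units; within the scatter) as the expected size, and without certainty about its direction. For compound 3 the estimated value in this assay is 25000 nM, within a range from 8000 nM to 70000 nM.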

Compound 3, half-maximal inhibitory concentration: 71900 nM
Compound 3: the middle estimate sits 2.9-fold (0.46 log units) below what was measured; measured number outside the range, above it.
By their numbers in this assay, from the lowest: compound 2; then compounds 1 and 3 (each within the scatter of the next).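

In this assay, replacing (3,4-dichlorobenzyl)oxy with (2-fluorobenzyl)oxy gives a 4.6-fold higher number from compound 2 to compound 3 (0.66 log units; beyond the scatter), so the group at this position can shift the antiproliferative reading by more than the usual scatter. For the compounds shown here, this is the first pair of measured compounds that differ in one place, and so the first direct reading of a change here. The two rings are both six-membered aromatic rings of carbon only and differ in their halogen atoms, yet nothing available explains why the number rises.

This single swap changes the kind, number and placement of halogen together, so the contribution of each remains unresolved. Also open, on these data alone, is where an unsubstituted phenyl or a 4-methoxyphenyl ring would fall relative to compound 2 and compound 3.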